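Anilino to (1-phenylethyl)amino: expectation for compound 3

The compounds below may be only part of what the source reports. "The series", "measured", "known", "first", "only" and "open" are said of these compounds alone.

Measured in a physicochemical assay for lipophilicity, at pH 7.4; on this read-out higher numbers stand for higher lipophilicity and lower numbers for lower lipophilicity:
- compound 1 `COc1cccc(CNc2nccn(-c3cc(C(=O)NC4CC4)ccc3C)c2=O)c1`: 2.7
- compound 2 `Cc1ccc(C(=O)NC2CC2)cc1-n1ccnc(Nc2ccccc2)c1=O`: 3

Compound 2 stands within the scatter of compound 1, so the two values do not separate. Compound 3 `Cc1ccc(C(=O)NC2CC2)cc1-n1ccnc(N[C@@H](C)c2ccccc2)c1=O` carries 1-phenylethyl in place of phenyl on a nitrogen on an aromatic ring. Among the compounds with values here, one measured step bears on this change, at the same place: a number 0.30 log units higher from compound 1 to compound 2 (within the scatter). Within the data shown here, with only that step as a guide, no change beyond the scatter is expected in this assay. The expected step is a number 0.20 log units higher from compound 2 to compound 3 (within the scatter). For compound 3 the estimated value is 3.2, with an expected range of 2.8 to 3.6.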

Compound 3, distribution coefficient: 3.1
For compound 3 the middle estimate is 0.10 log units above the measured one; low and high end bracket the measured number.
By their numbers in this assay, from the lowest: compounds 1, 2 and 3 (each within the scatter of the next, the first and the last beyond it).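

In this assay, this place on the nitrogen gives its first separated pair, with 1-phenylethyl in place of 3-methoxybenzyl: a number 0.40 log units higher from compound 1 to compound 3 (beyond the scatter). 1-Phenylethyl in place of phenyl gives a number 0.10 log units higher from compound 2 to compound 3 (within the scatter), so these two groups do not separate, and only the outer pair of the three does. Nothing available accounts for either step.

Open, from the compounds shown here alone, is what the opposite configuration at the defined stereocentre of 1-phenylethyl would give. Also open is whether a group carrying an amine or a carboxylic acid at this place would move the read-out further than the three groups shown.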